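Longer Ester Chains and Weaker Cytotoxicity in Lung Cells

A few compounds are considered here, and "the series" means these few. Any claim that something is new, unique, unknown or untested is made for them only; others in the source may bear on it.

Measured so far:
compound 1 `CCCCCCCCOC(=O)CCC(=O)N1CCN(CCCOc2cc3c(Nc4ccc(F)c(Cl)c4)ncnc3cc2OC)CC1`: 21.7%
compound 2 `CCCCCCCCCCCCCCOC(=O)CCC(=O)N1CCN(CCCOc2cc3c(Nc4ccc(F)c(Cl)c4)ncnc3cc2OC)CC1`: 77.2%

In a functional assay on A549 cells (Homo sapiens) for cytotoxicity, read by MTT assay, with a stated time of 24 h, tested at 80 uM (on this read-out higher numbers stand for a weaker effect at the one concentration tested and lower numbers for a stronger effect), compound 2 stands highest of the two numbers shown, meaning the weaker effect of the pair; its nearest neighbour is compound 1, and the one measured step, a number 55.5 percentage points higher from compound 1 to compound 2 (beyond the scatter), was large and lay beyond the scatter. Compound 3 `CCCCCCCCCCCCCCCCCCCOC(=O)CCC(=O)N1CCN(CCCOc2cc3c(Nc4ccc(F)c(Cl)c4)ncnc3cc2OC)CC1` is the next member of this series, differing from compound 2 by pentyl in place of hydrogen on a saturated chain carbon, ten or more bonds along the chain from an oxygen next to a carbonyl group. Within the data shown here, the only step that bears on this change is a number 55.5 percentage points higher from compound 1 to compound 2 (beyond the scatter), where lengthening the same chain went with a much weaker effect. Compound 2 already sits near the top of the percentage scale, so the step of a number 10.8 percentage points higher from compound 2 to compound 3 (beyond the scatter) is expected to run in the same direction but to be smaller in size. On that basis compound 3 is estimated at 88%, within a range from 72% to 100%.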

Compound 3, a percentage reported as activity, at one concentration (the size of the read-out at that concentration, not a potency): 88.4%
Beside the measured number, compound 3's estimate is 0.4 percentage points below it, and the stated range covers the measured number.
By their numbers in this assay, from the lowest: compound 1; then compound 2; then compound 3.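

In this assay, pentyl in place of hydrogen on a saturated chain carbon, ten or more bonds along the chain from an oxygen next to a carbonyl group, gives a number 11.2 percentage points higher from compound 2 to compound 3 (beyond the scatter), so the weakening of the effect continues past compound 2, although this step is only modest. Taken as a whole, the full lengthening of the chain gives a number 66.7 percentage points higher from compound 1 to compound 3 (beyond the scatter), and none of the three compounds goes against this order by chain length. Nothing available explains why the read-out follows the chain in this way.

The compounds shown leave open how a shorter chain would behave, and whether a still longer chain would change the read-out further. They also leave open whether a chain ending in an amine or a carboxylic acid would follow the same order.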